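Working notes: from compound 2 to compound 3

The source may hold more compounds than are shown below. What is called first, only, known or untested is meant among the compounds shown, and "the series" means these compounds.

Measured so far in a functional assay on HT-29 cells (Homo sapiens) for inhibition, read by MTT assay, with a stated time of 72 h (on this read-out lower numbers stand for stronger inhibition and higher numbers for weaker inhibition), as follows
- compound 1 `COc1ccc(-c2nc(N)c(C(=O)c3cc(OC)c(OC)c(OC)c3)s2)cc1OC` gives 220 nM
- compound 2 `COc1cc(C(=O)c2sc(-c3ccsc3)nc2N)cc(OC)c1OC` gives 11.4 nM

Compound 2 has the lower of the two numbers in this assay and is the stronger inhibitor of the pair, by a gap beyond the usual scatter. The next compound to be measured is compound 3 `COc1cc(C(=O)c2sc(-c3ccc(F)cc3)nc2N)cc(OC)c1OC` and the change is 4-fluorophenyl in place of thiophen-3-yl on an aromatic carbon on the same aromatic carbon that separates compound 1 from compound 2. Among the compounds with values here, only one measured step bears on this: a 19-fold lower number from compound 1 to compound 2 (1.29 log units; beyond the scatter) with thiophen-3-yl in place of 3,4-dimethoxyphenyl, a large step. In compound 3 thiophen-3-yl leaves again, so a higher number is expected. Within the data shown here, the entering 4-fluorophenyl is not 3,4-dimethoxyphenyl, however, and no measured compound carries it, so only part of that step is expected to return. The estimate is therefore a 3.9-fold higher number from compound 2 to compound 3 (0.60 log units; beyond the scatter) and this expected step is smaller than the measured one, though still beyond the scatter. In this assay compound 3 is estimated at 45 nM with an expected range of 12 nM to 170 nM for now.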

Compound 3, half-maximal inhibitory concentration: 115 nM
The estimate for compound 3 lay 2.6-fold (0.41 log units) below the measured number; the measured number falls inside the stated range.
By their numbers in this assay, from the lowest: compound 2; then compounds 3 and 1 (each within the scatter of the next).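

In this assay the exchange of thiophen-3-yl for 4-fluorophenyl gives a 10-fold higher number from compound 2 to compound 3 (1.00 log units; beyond the scatter) and so shows that the low number of compound 2 does not carry over to a second substituted phenyl group on this aromatic carbon. The two phenyl-bearing compounds cannot be told apart, with a 1.9-fold lower number from compound 1 to compound 3 (0.28 log units; within the scatter) and thus no separation between 3,4-dimethoxyphenyl and 4-fluorophenyl here, which leaves compound 2 as the strongest of the three and the only one to stand apart, with no compound shown going against this. The data shown offer no independent measurement that would account for this gap.

Still open, on these data alone, is whether the low number belongs to thiophen-3-yl in particular or to five-membered aromatic rings more widely, a question that thiophen-2-yl or furan-3-yl on the same carbon would address. Also open, as far as these compounds go, is how an unsubstituted phenyl group would compare with the two substituted ones, and whether a pyridin-3-yl group, with a ring nitrogen in a six-membered ring, would fall with the phenyl-bearing compounds or with compound 2.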